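Working notes: compound 4, chloro in place of methoxy

The source may report more compounds than this note shows. Statements on the series, on what has been measured and on what is new or still open speak of the compounds shown alone.

Measured so far in a functional assay on RPMI 8402 cells (Homo sapiens) for cytotoxicity; on this read-out higher numbers stand for weaker inhibition and lower numbers for stronger inhibition:
- compound 1 `COc1ccc(-c2ccc3[nH]c(-c4ccc5[nH]c(-c6ccc7[nH]cnc7c6)nc5c4)nc3c2)cc1`: 90 nM
- compound 2 `c1ccc(-c2ccc3[nH]c(-c4ccc5[nH]c(-c6ccc7[nH]c(-c8ccccc8)nc7c6)nc5c4)nc3c2)cc1`: 60 nM
- compound 3 `Cc1nc2cc(-c3nc4cc(-c5nc6cc(-c7ccccc7)ccc6[nH]5)ccc4[nH]3)ccc2[nH]1`: 110 nM

Compound 1 stands second highest of the three numbers in this assay; its nearest neighbour is compound 3, its furthest compound 2, and both gaps lie within the scatter. For the measured compounds named here, the only single-point step in the set is a 1.8-fold higher number from compound 2 to compound 3 (0.26 log units; within the scatter), a methyl for a phenyl, which likewise stays within the scatter; the three measured compounds therefore sit as one cluster.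

Compound 4 `Clc1ccc(-c2ccc3[nH]c(-c4ccc5[nH]c(-c6ccc7[nH]cnc7c6)nc5c4)nc3c2)cc1` differs from compound 1 by chloro in place of methoxy on an aromatic carbon. Going by the values given here, no measured pair in the set swaps one substituent on that outer phenyl for another, so there is no step that bears directly on this change, and the step that does exist is flat. The expectation for this assay is therefore no step beyond the scatter, and the estimated step is no change at the digits printed from compound 1 to compound 4 (within the scatter). Compound 4 is estimated at 90 nM, with a range from 40 nM to 200 nM.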

Compound 4, half-maximal inhibitory concentration: 90 nM
For compound 4 middle estimate and measured number coincide at the digits printed; the measured number falls inside the stated range.
By their numbers in this assay, from the lowest: compounds 2, 1, 4 and 3 (each within the scatter of the next).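

Chloro in place of methoxy, on an aromatic carbon para to a large group, gives in this assay no change at the digits printed from compound 1 to compound 4 (within the scatter). For the compounds shown here, this is the first step read at this position, and it shows that, in this pair, a group with a hydrogen-bond acceptor can give way to one without, with no step beyond the scatter. No measured evidence speaks to the reason for this flat step.

One pair does not settle whether an amine, a carboxylic acid or a longer chain such as butoxy at this position would also stay within the scatter. As far as these compounds go, whether chloro in place of methoxy would read the same on the core of compound 3 also stays open.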